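The source may report more compounds than this note shows. Statements on the series, on what has been measured and on what is new or still open speak of the compounds shown alone.

Of the compounds shown here, three built on one shared core have been tested in an ADME assay on SK-OV-3 cells (Homo sapiens) for cytotoxicity, read by sulforhodamine B assay, with a stated time of 48 h, tested at 10 uM; a lower number here means less inhibition, a higher number more inhibition at the concentration tested (going by the name of the read-out). Compound 1 `CCCCc1cn(C(c2ccccc2)c2cc3cc(Br)ccc3nc2OC)nn1` gives 11.1%. Compound 2 `COc1nc2ccc(Br)cc2cc1C(c1ccccc1)n1cc(-c2ccc(F)cc2)nn1` gives 14.3%. Compound 3 `COc1nc2ccc(Br)cc2cc1C(c1ccccc1)n1cc(-c2ccccc2)nn1` gives 13.7%. Among these three numbers compound 3 stands second highest; its nearest neighbour is compound 2, and a number 0.6 percentage points lower from compound 2 to compound 3 (within the scatter) lies within the scatter, as does a number 2.6 percentage points higher from compound 1 to compound 3 (within the scatter). None of the three separates itself from the others.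

Compound 4 `CCCc1cn(C(c2ccccc2)c2cc3cc(Br)ccc3nc2OC)nn1` has not yet been measured in this assay. It differs from compound 3 in a single place: propyl in place of phenyl on an aromatic carbon. The step that bears most directly on this change is a number 2.6 percentage points higher from compound 1 to compound 3 (within the scatter), which accompanied phenyl in place of butyl on the same aromatic carbon; the present change runs in the opposite sense, with propyl arriving in place of phenyl. The related step of a number 3.2 percentage points higher from compound 1 to compound 2 (within the scatter) was likewise within the scatter. On this basis the change from compound 3 to compound 4 is expected to produce no step beyond the scatter, a number 1.7 percentage points lower from compound 3 to compound 4 (within the scatter). The number for compound 4 in this assay is therefore estimated at 12%, with a range from 4% to 20%.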

Compound 4, a percentage reported as inhibition, at one concentration (the size of the read-out at that concentration, not a potency): 11.2%
Estimate against measurement, compound 4: 0.8 percentage points above; low and high end bracket the measured number.
By their numbers in this assay, from the lowest: compounds 1, 4, 3 and 2 (each within the scatter of the next).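

In this assay, among the compounds shown here, propyl on the aromatic carbon of the five-membered aromatic ring with 3 nitrogen gives the first direct comparison of a three-carbon chain with the two aromatic groups at this place: a number 2.5 percentage points lower from compound 3 to compound 4 (within the scatter) and a number 3.1 percentage points lower from compound 2 to compound 4 (within the scatter) both show that swapping a six-membered aromatic ring of carbon only for propyl does not separate the compounds. For the compounds shown here, the comparison between the two saturated chains, which the earlier compounds could not supply, gives a number 0.1 percentage points higher from compound 1 to compound 4 (within the scatter), so butyl and propyl cannot be told apart here either. No measurement shown accounts for this lack of separation among the four compounds.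

Going by these compounds, the four groups at this place are butyl, propyl, phenyl and 4-fluorophenyl, so it remains open whether an amine, a carboxylic acid or a much longer chain there would give a step beyond the scatter in this assay. Because every comparison rests on a single tested concentration, the compounds shown also leave open whether these groups would differ at any other concentration.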